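Shortening the nitrooxy chain of a feruloyl ester

The source may report more compounds than this note shows. Statements on the series, on what has been measured and on what is new or still open speak of the compounds shown alone.

Of the compounds shown here, three share a feruloyl ester core and have been measured in a functional assay on LOX IMVI cells (Homo sapiens) for cytotoxicity, read by resazurin assay, with a stated time of 72 h; on this read-out lower numbers stand for stronger inhibition and higher numbers for weaker inhibition. Compound 1 `COc1cc(/C=C/C(=O)OC(C)CCOc2no[n+]([O-])c2S(=O)(=O)c2ccccc2)ccc1O` gives 410 nM. Compound 3 `COc1cc(/C=C/C(=O)OC/C=C/CO[N+](=O)[O-])ccc1O` gives 2360 nM, the highest of the two numbers, standing well beyond the scatter from compound 1. For compound 2 `COc1cc(/C=C/C(=O)OCCCCCO[N+](=O)[O-])ccc1OCCCCCO[N+](=O)[O-]` this assay reports only a limit, > 50000 nM, and no number; this is the limit of > 50000 nM in this assay, at which 1 of the 3 values shown sits.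

Compound 4 `COc1cc(/C=C/C(=O)OCCCO[N+](=O)[O-])ccc1O` has not yet been measured. It differs from compound 3 in one place: a group of 6 heavy atoms (2 carbon, 1 nitrogen, 3 oxygen; no ring) in place of a group of 7 heavy atoms (3 carbon, 1 nitrogen, 3 oxygen; no ring), on a saturated chain carbon bound to an oxygen next to a carbonyl group.

For the measured compounds named here, no step between measured compounds bears on this change, so the account rests on compound 3 alone. Compound 4 is expected to stay near compound 3 in this assay, with a step from compound 3 to compound 4 of a 1.5-fold higher number from compound 3 to compound 4 (0.17 log units; within the scatter), leaning toward a weaker result. The estimate for compound 4 in this assay is 3500 nM, within a range from 1000 nM to 15000 nM.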

Compound 4, half-maximal inhibitory concentration: 29500 nM
Compound 4: middle estimate off by 8.4-fold (0.93 log units), on the low side, outside the stated range (above it).
By their numbers in this assay, from the lowest: compound 1; then compound 3; then compound 4. At a limit, above all of these: compound 2.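

On the saturated chain carbon bound to an oxygen next to a carbonyl group, the change to 2-(nitrooxy)ethyl gives a 13-fold higher number from compound 3 to compound 4 (1.10 log units; beyond the scatter) in this assay. For the compounds shown here, this is the first direct sign that this position of the ester responds strongly to a small change in the nitrooxy chain. The group that leaves and the group that enters have the same nitrogen and oxygen counts and the same hydrogen-bond counts, so the large step goes with a difference only in carbon count and double bonds, and nothing measured here gives its cause.

The compounds shown leave open whether chain length or the double bond carries the step. A 4-(nitrooxy)butyl ester on the shared core would separate the two.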